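Cytotoxicity notes: cyclobutyl to cyclopropylmethyl on the shared core

A few compounds are considered here, and "the series" means these few. Any claim that something is new, unique, unknown or untested is made for them only; others in the source may bear on it.

Measured compounds:
- compound 1 `CC(C)S(=O)(=O)n1c(=O)n(Cc2nc3ccccc3n2CCCC#N)c2cnccc21`: > 228000 nM
- compound 2 `N#CCCCn1c(Cn2c(=O)n(C3CCC3)c3ccncc32)nc2ccccc21`: > 258000 nM

In an ADME assay on HEp-2 cells (Homo sapiens) for cytotoxicity (a lower number here means that less compound is tolerated, a higher number that more compound is tolerated), compound 1 gives > 228000 nM, which is a limit of the assay. In this assay compound 2 likewise gives > 258000 nM, again a limit and not a number. Within the data shown here, the one measured change, a step that the two limits leave unreadable from compound 1 to compound 2, therefore cannot be sized, because both ends rest on limits the limit of > 228000 nM in this assay, at which 1 of the 2 values shown sits (the limit of > 258000 nM in this assay, at which 1 of the 2 values shown sits). Compound 2 stands at the upper edge of what was measured, with nothing in the series showing a readable toxic concentration.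

Compound 3 `N#CCCCn1c(Cn2c(=O)n(CC3CC3)c3ccncc32)nc2ccccc21` is the next case, differing from compound 2 by cyclopropylmethyl in place of cyclobutyl on an aromatic nitrogen. Among the measured compounds shown here, no measured step bears directly on this exchange; the only step in hand is unreadable. With both neighbours at limits, a step of no readable size in this assay is expected, an at least 1.0-fold lower number from compound 2 to compound 3 (0.01 log units; that floor lies within the scatter). Compound 3 is estimated at 250000 nM, between 100000 nM and 600000 nM, most likely reported as a limit.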

Compound 3, half-maximal cytotoxic concentration: 96500 nM
Beside the measured number, compound 3's estimate is 2.6-fold (0.41 log units) above it; measured number outside the range, below it.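

In this assay, among these compounds, compound 3 gives 96500 nM, the first value that is a number and not a limit, so the group on this aromatic nitrogen can shift the read-out even when no atoms are gained or lost. Cyclopropylmethyl in place of cyclobutyl gives an at least 2.6-fold lower number from compound 2 to compound 3 (0.42 log units; beyond the scatter), and cyclopropylmethyl in place of isopropylsulfonyl gives an at least 2.3-fold lower number from compound 1 to compound 3 (0.37 log units; beyond the scatter). The first of these steps is only a floor because compound 2 rests on a limit: the limit of > 258000 nM in this assay, at which 1 of the 3 values shown sits.

Going by these compounds, the step between compound 1 and compound 2 still cannot be read, and the full size of both new steps stays open. On these data alone, whether a longer chain such as cyclobutylmethyl, or an amine or a carboxylic acid, on this nitrogen would give a readable number also remains open.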